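A few compounds are considered here, and "the series" means these few. Any claim that something is new, unique, unknown or untested is made for them only; others in the source may bear on it.

Compound 1 `O=S(=O)(CCC(F)(Cl)C(F)(F)Cl)c1nc2ccccc2s1` in a functional assay on MCF7 cells (Homo sapiens) for cytotoxicity, read by MTT assay, with a stated time of 48 h; a lower number here means a stronger inhibitor, a higher number a weaker inhibitor: 10100 nM
Compound 2 `FC(F)=C(F)CCSc1nc2ccc(OC(F)F)cc2[nH]1`: > 120000 nM, a limit of the assay
Compound 3 `FC(F)=C(F)CCSc1ncc(-c2ccncc2)s1`: > 120000 nM, also a limit of the assay

Among the compounds with values here, compound 1 stands as the only compound with a measured number. The other two values sit at the limit of > 120000 nM in this assay, at which 2 of the 3 values shown sit. Within the data shown here, no pair of measured compounds differs in one place, so no single change has been tested here.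

Compound 4 `O=S(=O)(CCC(F)(Cl)C(F)(F)Cl)c1nc2ccc(Cl)cc2s1` differs from compound 1 by chloro in place of hydrogen on an aromatic carbon. Among the measured compounds shown here, with no measured step to lean on, the step is expected to be modest, a 1.4-fold lower number from compound 1 to compound 4 (0.16 log units; within the scatter), lying within or only slightly beyond the scatter, and if anything toward a stronger inhibitor. Compound 4 is therefore estimated at 7000 nM, within a range from 2500 nM to 20000 nM.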

Compound 4, half-maximal inhibitory concentration: 8400 nM
Beside the measured number, compound 4's estimate is 1.2-fold (0.08 log units) below it; measured number inside the range.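

In this assay, chloro in place of hydrogen on an aromatic carbon of the six-membered ring gives a 1.2-fold lower number from compound 1 to compound 4 (0.08 log units; within the scatter) and leaves the two values within the scatter of each other. Within the data shown here, this place on the core therefore carries a chloro with no step beyond the scatter, something the earlier compounds, with no single change among them, could not show.

Going by these compounds, whether a methoxy, an amine or a carboxylic acid at the same place would read alike remains open. Nothing shown gives a reason for this result.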